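Side-chain swap from compound 3 to compound 4

This account rests on a few compounds, and the source may have more. Where it says the series, first, only, none or still open, it means among the compounds named here.

- compound 1 (`CC(C)CCOc1ccccc1C1CC(=O)c2ccccc2O1`) gives 39200 nM
- compound 2 (`CCCOc1ccccc1C1CC(=O)c2ccccc2O1`) gives 46000 nM
- compound 3 (`CC(C)c1ccc(COc2ccccc2C2CC(=O)c3ccccc3O2)cc1`) gives 27100 nM

All three values come from a functional assay on RAW264.7 cells (Mus musculus) for inhibition, read by Griess assay, with stated times of 1 h and 24 h (a higher number here means a weaker inhibitor, a lower number a stronger inhibitor), and share one core. Compound 3 has the lowest number of the three, but it lies within the scatter of both other compounds, so the set cannot be ranked.

The next compound is compound 4 (`CC(C)COc1ccccc1C1CC(=O)c2ccccc2O1`). The change from compound 3 is isopropyl in place of 4-isopropylphenyl on a saturated chain carbon bound to an oxygen on an aromatic ring.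

Within the data shown here, two measured steps bear on this most directly, since each puts 4-isopropylphenyl at that same place in exchange for an alkyl group (a 1.4-fold lower number from compound 1 to compound 3 (0.16 log units; within the scatter); a 1.7-fold lower number from compound 2 to compound 3 (0.23 log units; within the scatter)). Both lie within the scatter. The step between the two alkyl compounds is also within the scatter (a 1.2-fold higher number from compound 1 to compound 2 (0.07 log units; within the scatter)). Compound 4 carries an alkyl group as well, so a small move towards their values is expected, with nothing beyond the scatter.

The expected step is a 1.5-fold higher number from compound 3 to compound 4 (0.17 log units; within the scatter) in this assay and would be a slightly higher number.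

Compound 4 is estimated at 40000 nM in this assay, with an expected range from 25000 nM to 65000 nM for that estimate.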

Compound 4, half-maximal inhibitory concentration: 36700 nM
Beside the measured number, compound 4's estimate is 1.1-fold (0.04 log units) above it; the range from low to high includes it.
By their numbers in this assay, from the lowest: compounds 3, 4, 1 and 2 (each within the scatter of the next).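

In this assay, all three new steps stay within the scatter: a 1.4-fold higher number from compound 3 to compound 4 (0.13 log units; within the scatter), a 1.3-fold lower number from compound 2 to compound 4 (0.10 log units; within the scatter) and a 1.1-fold lower number from compound 1 to compound 4 (0.03 log units; within the scatter). The swap from 4-isopropylphenyl to isopropyl takes out one six-membered aromatic ring of carbon only and goes from 9 heavy atoms to 3, yet gives no readable change, so the large aryl group at this place on a saturated chain carbon bound to an oxygen on an aromatic ring shows no advantage over a small alkyl group. The step from compound 2 adds a second reading: methyl in place of hydrogen on a saturated chain carbon bound to two saturated chain carbons also gives no readable change, and nothing on hand offers a reason for so flat a response.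

Every group shown at this place consists of carbon and hydrogen only, so the series cannot yet say whether the number responds to anything at this position. An amine or a carboxylic acid on this chain, or a much longer chain, would test whether any group here moves the number beyond the scatter.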